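A few compounds are considered here, and "the series" means these few. Any claim that something is new, unique, unknown or untested is made for them only; others in the source may bear on it.

Of the compounds shown here, three sharing one core have been tested in a functional assay on the whole organism (artery) for inhibition, with Rattus norvegicus as the target, at a dose of 3 mg/kg by the intraduodenal route; a lower number here means less inhibition, a higher number more inhibition at the dose given (going by the name of the read-out). Compound 1 `CCCCc1ccc(CNS(C)(=O)=O)c(=O)n1Cc1ccc(-c2ccccc2-c2nn[nH]n2)cc1` gives 54.8%. Compound 2 `CCCCc1ccc(CN(Cc2ccccc2)S(=O)(=O)c2ccccc2)c(=O)n1Cc1ccc(-c2ccccc2-c2nn[nH]n2)cc1` gives 75.7%. Compound 3 `CCCCc1ccc(CN)c(=O)n1Cc1ccc(-c2ccccc2-c2nn[nH]n2)cc1` gives 2.8%, the lowest of the three numbers, with compound 1 the nearest and compound 2 the furthest above it, both beyond the scatter. Among the compounds with values here, the one traced step, a number 52 percentage points lower from compound 1 to compound 3 (beyond the scatter), comes from hydrogen in place of methylsulfonyl on an amine nitrogen: leaving that nitrogen with only hydrogen removed most of the inhibition.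

Compound 4 `CCCCc1ccc(CNC(=O)NC2CCCCC2)c(=O)n1Cc1ccc(-c2ccccc2-c2nn[nH]n2)cc1` differs from compound 3 by cyclohexylcarbamoyl in place of hydrogen on an amine nitrogen. Within the data shown here, that step from compound 1 to compound 3 is the one measured change at the same place, and it was large. Among the measured compounds shown here, the values of compound 2 and compound 3 point the same way, as compound 2 carries a still bulkier pair of groups on that nitrogen and stands higher again, though no single step is traced between them. A rise of comparable size is therefore expected for compound 4 because a number 52 percentage points lower from compound 1 to compound 3 (beyond the scatter) shows how much the read-out depends on filling that nitrogen. Compound 4 is estimated to give 50%, within 25% to 75%. This expected change amounts to a number 47.2 percentage points higher from compound 3 to compound 4 (beyond the scatter).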

Compound 4, a percentage reported as inhibition, in the whole organism at one dose (the size of the read-out at that dose, not a potency): 0%
Compound 4: middle estimate off by 50 percentage points, on the high side; measured number below the stated range.
By their numbers in this assay, from the lowest: compounds 4 and 3 (each within the scatter of the next); then compound 1; then compound 2.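

In this assay, filling the amine nitrogen is not enough on its own: cyclohexylcarbamoyl in place of hydrogen gives a number 2.8 percentage points lower from compound 3 to compound 4 (within the scatter). What is attached to that nitrogen therefore matters, not merely that something is attached, since cyclohexylcarbamoyl in place of methylsulfonyl gives a number 54.8 percentage points lower from compound 1 to compound 4 (beyond the scatter), a large step at a single position. Nothing measured here explains why these two groups on the same nitrogen part so far.

The compounds shown leave open whether a small acetyl or methylcarbamoyl group on this nitrogen would behave like methylsulfonyl or like cyclohexylcarbamoyl, which would separate the effect of the carbonyl-linked type of group from that of the cyclohexyl ring. They also leave open what a phenylsulfonyl group alone on the nitrogen, without the benzyl group that compound 2 carries as well, or a cyclohexylsulfonyl group, would give, and so whether the sulfonyl link itself goes with the higher numbers.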